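The compounds below may be only part of what the source reports. "The series", "measured", "known", "first", "only" and "open" are said of these compounds alone.

Three measured compounds share one core and differ only in the aromatic ring on the amide carbonyl carbon. In a functional assay on HepG2 cells (Homo sapiens) for antiproliferative activity, read by CCK-8 assay, with a stated time of 72 h (a lower number here means a stronger inhibitor, a higher number a weaker inhibitor), compound 1 `O=C(Nc1cccc(-c2oc3cc(-c4ccc(F)cc4)ccc3c(=O)c2O)c1)c1ccccc1F` gives 10100 nM, compound 2 `COc1ccc(C(=O)Nc2cccc(-c3oc4cc(-c5ccc(F)cc5)ccc4c(=O)c3O)c2)cc1` gives 8420 nM, and compound 3 `COc1ccccc1C(=O)Nc1cccc(-c2oc3cc(-c4ccc(F)cc4)ccc3c(=O)c2O)c1` gives 14500 nM. Compound 3 has the highest of the three numbers, yet its gaps to the other two stay within the scatter. Compound 4 `O=C(Nc1cccc(-c2oc3cc(-c4ccc(F)cc4)ccc3c(=O)c2O)c1)c1ccc(C(F)(F)F)cc1` differs from compound 3 by 4-(trifluoromethyl)phenyl in place of 2-methoxyphenyl on a carbonyl carbon. Among the compounds with values here, two measured steps bear on swapping this ring: a 1.2-fold lower number from compound 1 to compound 2 (0.08 log units; within the scatter) and a 1.7-fold higher number from compound 2 to compound 3 (0.24 log units; within the scatter), both within the scatter, as is a 1.4-fold higher number from compound 1 to compound 3 (0.16 log units; within the scatter). Nothing seen so far suggests that changing this ring moves the number beyond the scatter, so the expected step is a 1.4-fold lower number from compound 3 to compound 4 (0.14 log units; within the scatter). Compound 4 is estimated at 10500 nM, within a range from 4500 nM to 25000 nM.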

Compound 4, half-maximal inhibitory concentration: 42700 nM
For compound 4 the middle estimate is 4.1-fold (0.61 log units) below the measured one; the whole stated range lies below it.
By their numbers in this assay, from the lowest: compounds 2, 1 and 3 (each within the scatter of the next); then compound 4.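

The earlier rings on the amide carbonyl carbon stayed within the scatter of one another, but this position does respond to the ring it carries. Putting in 4-(trifluoromethyl)phenyl gives a 2.9-fold higher number from compound 3 to compound 4 (0.47 log units; beyond the scatter) and a 4.2-fold higher number from compound 1 to compound 4 (0.63 log units; beyond the scatter) and, where only trifluoromethyl replaces methoxy, a 5.1-fold higher number from compound 2 to compound 4 (0.71 log units; beyond the scatter). Compound 4 is therefore the weakest inhibitor of the four. Nothing available explains this loss. From the compounds shown here alone, whether another group on this ring, such as an amine or a carboxylic acid, could lower the number beyond the scatter remains open.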